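A few compounds are considered here, and "the series" means these few. Any claim that something is new, unique, unknown or untested is made for them only; others in the source may bear on it.

Measured in a functional assay on KB 3-1 cells (Homo sapiens) for cytotoxicity, read by MTT assay, with a stated time of 68 h; on this read-out lower numbers stand for stronger inhibition and higher numbers for weaker inhibition:

Compound 1 `Nc1cccc(-c2cccc(NC(=O)C(Cl)Cl)c2)c1`: 26100 nM
Compound 2 `O=C(Nc1cccc(-c2cccc(F)c2)c1)C(Cl)Cl`: > 50000 nM (a limit of the assay, not a number)
Compound 3 `COc1cccc(-c2cccc(NC(=O)C(Cl)Cl)c2)c1`: 43300 nM

All three compounds share one core and differ in a single group on an aromatic carbon. Going by the values given here, compound 3, at 43300 nM, lies within the scatter of the only other exact number in the set: a 1.7-fold higher number from compound 1 to compound 3 (0.22 log units; within the scatter). Compound 2 gave no exact number, only the limit (the limit of > 50000 nM in this assay, at which 1 of the 3 values shown sits).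

Compound 4 `O=C(Nc1cccc(-c2cccc(C(F)(F)F)c2)c1)C(Cl)Cl` is the next to be tested, with trifluoromethyl in place of methoxy on an aromatic carbon. The closest guide is what the earlier exchanges at this place did in this assay. Going an at least 1.9-fold higher number from compound 1 to compound 2 (0.28 log units; that floor lies within the scatter) and going an at least 1.1-fold lower number from compound 2 to compound 3 (0.06 log units; that floor lies within the scatter) gave floors within the scatter, and the step of a 1.7-fold higher number from compound 1 to compound 3 (0.22 log units; within the scatter) also stayed within it. None of these three steps therefore shows a real change, and trifluoromethyl is a new group whose effect they cannot fix closely.

The expected result is no change beyond the scatter: a 1.1-fold lower number from compound 3 to compound 4 (0.03 log units; within the scatter). Like compound 2, compound 4 may be reported only as a limit. The estimated value for compound 4 is 40000 nM, with an expected range of 20000 nM to 70000 nM.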

Compound 4, half-maximal inhibitory concentration: > 50000 nM
Compound 4 was reported as a limit (the forecaster's own chance of this, stated with the estimate: 45%); middle value at least 1.2-fold (0.09 log units) away from the limit.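

Compound 4, with trifluoromethyl, is reported as a limit, like compound 2 with fluoro, so both fluorine-bearing groups at this position in this assay end there, while amino and methoxy give exact numbers: the limit of > 50000 nM in this assay, at which 2 of the 4 values shown sit.

Measured against those two exact numbers, the new group gives an at least 1.1-fold higher number from compound 3 to compound 4 (0.06 log units; that floor lies within the scatter) and an at least 1.9-fold higher number from compound 1 to compound 4 (0.28 log units; that floor lies within the scatter), so neither floor shows a real change, although each step could be larger than its floor. The step between compound 2 and compound 4 cannot be read, as both values are limits.

The true numbers for compound 2 and compound 4 remain open, so none of the groups shown at this position has yet produced a step beyond the scatter. Also open, from the compounds shown here alone, is whether a carboxylic acid, a nitrile or a longer chain such as ethoxy on this same aromatic carbon would give a number clearly different from that of compound 1, at 26100 nM.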